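The source may report more compounds than this note shows. Statements on the series, on what has been measured and on what is new or still open speak of the compounds shown alone.

Three compounds that share one core and differ only in the substituted phenyl group on it have been tested in an ADME assay on microsomes from liver (Rattus norvegicus) for metabolic stability, read by LC-MS, using NADPH, at 37 degrees C; on this read-out higher numbers stand for a longer-lived compound and lower numbers for a shorter-lived compound. Compound 1 `Cc1oc(-c2ccccc2Cl)nc1CN1CCC(C(=O)NCCCN2C[C@H](C)C[C@H](C)C2)CC1` gives 0.25 h, compound 2 `Cc1oc(-c2c(Cl)cccc2Cl)nc1CN1CCC(C(=O)NCCCN2C[C@H](C)C[C@H](C)C2)CC1` gives 0.0483 h, and compound 3 `COc1cccc(F)c1-c1nc(CN2CCC(C(=O)NCCCN3C[C@H](C)C[C@H](C)C3)CC2)c(C)o1` gives 0.143 h. Compound 3 thus sits within the scatter of compound 1 and clearly above compound 2.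

The next step leads to compound 4 `Cc1ccc(-c2nc(CN3CCC(C(=O)NCCCN4C[C@H](C)C[C@H](C)C4)CC3)c(C)o2)cc1C`, with 3,4-dimethylphenyl in place of 2-fluoro-6-methoxyphenyl on an aromatic carbon.

Three measured steps change this same group. The first runs a 1.7-fold lower number from compound 1 to compound 3 (0.24 log units; within the scatter), the second 5.2-fold lower number from compound 1 to compound 2 (0.71 log units; beyond the scatter), and the third 3.0-fold higher number from compound 2 to compound 3 (0.47 log units; beyond the scatter). All three are small or modest, but none of these compounds carries methyl groups on the phenyl, so they give only a rough guide to size and little guide to direction. No change beyond the scatter is therefore expected, perhaps a slight drop, and the expected step is a 1.2-fold lower number from compound 3 to compound 4 (0.08 log units; within the scatter). For compound 4 the estimated half-life is 0.12 h, with an expected range from 0.05 h to 0.3 h.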

Compound 4, half-life: > 0.5 h
Compound 4: no number, only a limit; the forecaster's own chance of this, stated with the estimate: 5%; middle value at least 4.1-fold (0.61 log units) away from the limit.
By their numbers in this assay, from the lowest: compound 2; then compounds 3 and 1 (each within the scatter of the next). At a limit, above all of these: compound 4.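

For compound 4 the half-life in this assay is no number but a limit: the limit of > 0.5 h in this assay, at which 1 of the 4 values shown sits. Even so, the move to 3,4-dimethylphenyl at this position gives a clear rise over the two compounds with a substituent on each side of the phenyl attachment (compound 3: an at least 3.4-fold higher number from compound 3 to compound 4 (0.54 log units; beyond the scatter)) (compound 2: an at least 10-fold higher number from compound 2 to compound 4 (1.01 log units; beyond the scatter)), while the earlier steps among the chloro, fluoro and methoxy phenyl groups were modest at most. The floor against compound 1 is less telling (see an at least 2.0-fold higher number from compound 1 to compound 4 (0.30 log units; that floor lies within the scatter)), so that step alone shows no firm gain.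

On these data alone, the true half-life of compound 4 remains unknown, and these compounds cannot separate the effect of its two methyl groups from the loss of the chloro, fluoro and methoxy groups. As far as these compounds go, whether a plain phenyl, a single methyl, or an amine or carboxylic acid on the phenyl would behave alike stays open.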